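Fluoro Added Beside the Amide Aniline in a Cytotoxicity Series

The source may report more compounds than this note shows. Statements on the series, on what has been measured and on what is new or still open speak of the compounds shown alone.

Measured compounds:
Compound 1, `Cc1cc(=O)n(-c2ccccc2OC(F)(F)F)nc1C(=O)Nc1ccc(Oc2ncnc3[nH]ccc23)c(F)c1`: 16200 nM
Compound 2, `Cc1cc(=O)n(-c2ccccc2OC(F)(F)F)nc1C(=O)Nc1ccc(Oc2ncnc3c2ccn3C)cc1`: 25200 nM

In a functional assay on A549 cells (Homo sapiens) for cytotoxicity, read by MTT assay, with a stated time of 72 h (on this read-out higher numbers stand for weaker inhibition and lower numbers for stronger inhibition), compound 1 gives 16200 nM. In this assay compound 2 gives 25200 nM, the highest of the two numbers; the nearest is compound 1, whose number is lower by a margin that lies within the scatter, so the two show no real separation. Compound 1 and compound 2 differ in two places at once, so what the two values show is only that both sit in the same weak range.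

Compound 3, `Cc1cc(=O)n(-c2ccccc2OC(F)(F)F)nc1C(=O)Nc1ccc(Oc2ncnc3c2ccn3C)c(F)c1`, has not yet been measured. It arises from compound 2 by fluoro in place of hydrogen on an aromatic carbon. Compound 1 already carries the same fluoro on its aniline, with a different core, and its value is indistinguishable from that of compound 2. For the measured compounds named here, no step of this kind is known, and compound 1 offers no sign that the fluoro moves the number far. The step is therefore expected to be small, in no clear direction, and not beyond the scatter: a 1.2-fold lower number from compound 2 to compound 3 (0.08 log units; within the scatter). Compound 3 is estimated at 21000 nM, in the range 7000 nM to 60000 nM.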

Compound 3, half-maximal inhibitory concentration: > 60000 nM
Compound 3 was reported as a limit; the forecaster's own chance of this, stated with the estimate: 15%; middle value at least 2.8-fold (0.45 log units) from the limit.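

On the core carrying the methyl, fluoro in place of hydrogen on an aromatic carbon, ortho to a large group and meta to a large group, gives an at least 2.3-fold higher number from compound 2 to compound 3 (0.37 log units; beyond the scatter), so this position is shown for the first time by a direct one-place comparison, and the change lies beyond the scatter. With the fluoro held in place, methyl in place of hydrogen on an aromatic nitrogen gives an at least 3.7-fold higher number from compound 1 to compound 3 (0.56 log units; beyond the scatter), a one-place comparison that compound 1 and compound 2, which differ in two places, could not offer. In this assay both steps are lower bounds, since compound 3 has a limit of the assay and not a number: the limit of > 60000 nM in this assay, at which 1 of the 3 values shown sits.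

From the compounds shown here alone, how far the true value of compound 3 lies past that limit stays open, as does whether the fluoro step would hold on the core of compound 1, with its hydrogen on the aromatic nitrogen. Also open, going by these compounds, is how a chlorine or a methoxy group at the same aromatic carbon, or an ethyl group in place of the methyl on the nitrogen, would compare.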